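The source may hold more compounds than are shown below. What is called first, only, known or untested is meant among the compounds shown, and "the series" means these compounds.

Measured in a physicochemical assay for solubility, using the shake flask method, in simulated intestinal fluid, measured as kinetic solubility, with a stated time of 20 h, at pH 6.5; a lower number here means a less soluble compound, a higher number a more soluble compound:
- Compound 1 `Fc1ccc(Nc2cc3[nH]c(-c4cccc(C(F)(F)F)c4)nc3cn2)nc1`: >= 50000 nM (a limit of the assay, not a number)
- Compound 2 `O=C(O)c1ccc(Nc2cc3[nH]c(-c4cccc(C(F)(F)F)c4)nc3cn2)nc1`: 6000 nM
- Compound 3 `FC1(F)CCC(c2nc3cnc(Nc4ccc(C(F)(F)F)cn4)cc3[nH]2)C1`: 163000 nM

Compound 3 stands highest of the two actual numbers in this assay, and the gap down to compound 2 lies beyond the scatter. Compound 1 can only be placed by its limit, >= 50000 nM.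

Compound 4 `FC(F)(F)c1ccc(Nc2cc3[nH]c(C4CC4)nc3cn2)nc1` has not yet been measured. It differs from compound 3 at one place: cyclopropyl in place of 3,3-difluorocyclopentyl on an aromatic carbon. The group sits on an aromatic carbon of the five-membered aromatic ring, between two ring nitrogen atoms.

Within the data shown here, no measured step touches this group. Among the measured compounds shown here, the only step available, an at least 8.3-fold lower number from compound 1 to compound 2 (0.92 log units; beyond the scatter), concerns carboxy in place of fluoro on an aromatic carbon, so it gives no direct size for the present change. It does show that a single change can move the read-out well beyond the scatter.

For the measured compounds named here, compound 3, at 163000 nM, has the highest number so far, and compound 2, at 6000 nM, shows how much lower a close relative can lie. A moderate fall is therefore expected rather than a further rise, though with wide uncertainty. The expected change is a 2.3-fold lower number from compound 3 to compound 4 (0.37 log units; beyond the scatter). For compound 4 the estimated value is 70000 nM, with an expected range of 15000 nM to 200000 nM.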

Compound 4, solubility: 123000 nM
Compound 4: the middle estimate sits 1.8-fold (0.24 log units) below what was measured, within the range that was stated.
By their numbers in this assay, from the lowest: compound 2; then compounds 4 and 3 (each within the scatter of the next).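

In this assay, putting cyclopropyl in place of 3,3-difluorocyclopentyl on the aromatic carbon between two ring nitrogen atoms gives a 1.3-fold lower number from compound 3 to compound 4 (0.12 log units; within the scatter). This is the only step shown at this position, and it shows that the read-out stays within the scatter when a five-membered ring of carbon bearing fluorine gives way to a three-membered ring of carbon; the one earlier step, an at least 8.3-fold lower number from compound 1 to compound 2 (0.92 log units; beyond the scatter), concerned a different place and lay beyond the scatter. Nothing given here accounts for this result.

From the compounds shown here alone, what an amine, a carboxylic acid or a longer chain would do at this position stays open, as does whether the change from fluoro to carboxy would have a similar size in a compound carrying cyclopropyl or 3,3-difluorocyclopentyl. Going by these compounds, compound 1 remains a limit of the assay at >= 50000 nM, so its exact place in this assay also stays open.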